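Swapping the aryl amide for a tert-butyl oxazole

The source may hold more compounds than are shown below. What is called first, only, known or untested is meant among the compounds shown, and "the series" means these compounds.

Three analogues sharing one core have been measured in an assay on isolated protein for inhibition of Rho-associated protein kinase 2 (Homo sapiens), read by scintillation counting, radiometric assay and 33P incorporation, with a stated time of 40 min, in the presence of a further agent that is not named here; a higher number here means a weaker inhibitor, a lower number a stronger inhibitor. Compound 1 `O=C(COc1ccc2c(=O)ccoc2c1)Nc1cccc(NC(=O)c2ccccc2)c1` gives 16 nM. Compound 2 `O=C(COc1ccc2c(=O)ccoc2c1)Nc1cccc(NC(=O)c2ccc(F)cc2)c1` gives 54 nM, and compound 3 `O=C(COc1ccc2c(=O)ccoc2c1)Nc1cccc(NC(=O)c2ccc(OC(F)(F)F)cc2)c1` gives 77 nM. Compound 3 thus holds the highest number of the three: the step of a 4.8-fold higher number from compound 1 to compound 3 (0.68 log units; beyond the scatter) lies beyond the scatter, whereas the step of a 1.4-fold higher number from compound 2 to compound 3 (0.15 log units; within the scatter) does not. The step of a 3.4-fold higher number from compound 1 to compound 2 (0.53 log units; beyond the scatter) is likewise modest.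

Compound 4 `CC(C)(C)c1cc(C(=O)Nc2cccc(NC(=O)COc3ccc4c(=O)ccoc4c3)c2)no1` differs from compound 3 in one place: 5-(tert-butyl)-1,2-oxazol-3-yl in place of 4-(trifluoromethoxy)phenyl on a carbonyl carbon. Among the compounds with values here, none of the measured steps covers an exchange of this kind; they only show that changing what sits on the carbonyl carbon, through the steps of a 3.4-fold higher number from compound 1 to compound 2 (0.53 log units; beyond the scatter) and a 4.8-fold higher number from compound 1 to compound 3 (0.68 log units; beyond the scatter), moved the number by modest amounts. Which way compound 4 will move in this assay is therefore open, and the expectation is a step of a 1.3-fold lower number from compound 3 to compound 4 (0.11 log units; within the scatter), that is, no change beyond the scatter. Compound 4 is accordingly estimated at 60 nM, within a range of 15 nM to 250 nM.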

Compound 4, half-maximal inhibitory concentration: 5 nM
The estimate for compound 4 lay 12-fold (1.08 log units) above the measured number; measured number below the stated range.
By their numbers in this assay, from the lowest: compound 4; then compound 1; then compounds 2 and 3 (each within the scatter of the next).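

Substituting the phenyl of compound 1 with 4-fluoro or 4-trifluoromethoxy had only raised the number in this assay, whereas the 5-(tert-butyl)-1,2-oxazol-3-yl group on the same carbonyl carbon lowers it against all three aryl amides (a 15-fold lower number from compound 3 to compound 4 (1.19 log units; beyond the scatter); an 11-fold lower number from compound 2 to compound 4 (1.03 log units; beyond the scatter); a 3.2-fold lower number from compound 1 to compound 4 (0.51 log units; beyond the scatter)). The position therefore accepts more than a substituted or plain phenyl, and a five-membered aromatic ring with 2 hetero atoms bearing tert-butyl gives the lowest number of the four compounds. No evidence at hand explains this gain.

The tert-butyl group and the 1,2-oxazole ring enter together, which leaves open how much of the step belongs to each: a phenyl carrying tert-butyl, or the 1,2-oxazol-3-yl ring without it, would separate the two. Also open, going by these compounds, is how an amine or a carboxylic acid in place of the tert-butyl group would read.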